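Cycloheptyl for methylcyclohexenyl on the carbonyl: cytotoxicity notes

This account rests on a few compounds, and the source may have more. Where it says the series, first, only, none or still open, it means among the compounds named here.

Measured so far in an ADME assay on MT4 cells (Homo sapiens) for cytotoxicity, with a stated time of 5 days; on this read-out higher numbers stand for lower toxicity in this test and lower numbers for higher toxicity in this test:
compound 1 `CC1CC=C(C(=O)N(c2cc(C#CC(C)(C)C)sc2C(=O)O)C(C)C)CC1` gives > 20000 nM, a limit of the assay.
compound 2 `CC(C)(C)C#Cc1cc(N(C(=O)[C@H]2CC[C@H](C)CC2)[C@H]2CC[C@](O)(CO[C@H]3CCOC3)CC2)c(C(=O)O)s1` gives > 20000 nM, also a limit.
compound 3 `C[C@H]1CC[C@H](C(=O)N(c2cc(C#CC3(C(F)(F)F)CCC3)sc2C(=O)O)[C@H]2CC[C@H](Oc3ccc(=O)[nH]n3)CC2)CC1` gives > 20000 nM, also a limit.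

Compound 1 thus stands at the limit of this assay, with no number of its own. Among the compounds with values here, the same holds across the whole set, since every value sits at the same limit (the limit of > 20000 nM in this assay, at which 3 of the 3 values shown sit), so no measured step in this assay exists to draw on.

Compound 4 `CC(C)N(C(=O)C1CCCCCC1)c1cc(C#CC(C)(C)C)sc1C(=O)O` differs from compound 1 in one place: cycloheptyl in place of 4-methylcyclohex-1-en-1-yl on a carbonyl carbon. Within the data shown here, with no measured step to compare, the expected change from the methylcyclohexenyl to the cycloheptyl amide is none beyond the scatter, an expected step that the limit leaves unreadable from compound 1 to compound 4. Compound 4 is therefore estimated at 25000 nM, with a range from 10000 nM to 60000 nM, and most probably again a limit rather than a number.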

Compound 4, half-maximal cytotoxic concentration: > 20000 nM
Compound 4 was reported as a limit; the forecaster's own chance of this, stated with the estimate: 85%; the middle value is on the limit's open side.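

Compound 1 and compound 4 both sit at the limit of this assay, so no step can be read between them. The compounds shown leave open whether cycloheptyl and 4-methylcyclohex-1-en-1-yl differ at all on this read-out, and whether any change in the series brings a value off the limit.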